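Compound 2 to compound 3: changing the aryl group on nitrogen

A few compounds are considered here, and "the series" means these few. Any claim that something is new, unique, unknown or untested is made for them only; others in the source may bear on it.

Measured in a functional assay on HeLa cells (Homo sapiens) for antiproliferative activity, read by MTT assay, with a stated time of 72 h; on this read-out lower numbers stand for stronger inhibition and higher numbers for weaker inhibition:
- compound 1 `CCNC(=O)c1cc(Oc2ccc(NC(=O)c3nn(-c4cccc(F)c4)c(=O)cc3C)cc2)ccn1` gives 6870 nM
- compound 2 `CCCNC(=O)c1cc(Oc2ccc(NC(=O)c3nn(-c4ccccc4C)c(=O)cc3C)cc2F)ccn1` gives 24600 nM

Of the two measured compounds, compound 2 has the higher number (24600 nM) and so the weaker inhibition. Its gap to compound 1 (6870 nM) lies beyond the scatter. The two differ in more than one place, so that gap cannot be assigned to any single group.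

Compound 3 `CCCNC(=O)c1cc(Oc2ccc(NC(=O)c3nn(-c4cccc(C(F)(F)F)c4)c(=O)cc3C)cc2F)ccn1` has 3-(trifluoromethyl)phenyl in place of 2-methylphenyl on an aromatic nitrogen. For the measured compounds named here, no measured pair isolates this change, so its size in this assay has to be estimated. Going by the values given here, the only lower number available, from compound 1 (6870 nM), comes from a compound that also lacks 2-methylphenyl, which is weak support for a move in that direction.

A small move to a lower number is expected, estimated as a 1.9-fold lower number from compound 2 to compound 3 (0.28 log units; within the scatter) and close to the scatter. Compound 3 is estimated at 13000 nM (expected range 4500 nM to 35000 nM).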

Compound 3, half-maximal inhibitory concentration: 8000 nM
Beside the measured number, compound 3's estimate is 1.6-fold (0.21 log units) above it, and the stated range covers the measured number.
By their numbers in this assay, from the lowest: compounds 1 and 3 (each within the scatter of the next); then compound 2.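

In this assay, the aryl group on the aromatic nitrogen now has a measured effect: 3-(trifluoromethyl)phenyl in place of 2-methylphenyl gives a 3.1-fold lower number from compound 2 to compound 3 (0.49 log units; beyond the scatter), a modest step and the first in the series confined to one place. With the rest of compound 2 unchanged, this step belongs to the exchange of aryl groups alone, which the gap between compound 1 and compound 2 could not show, since those two differ in more than one place. Nothing in the data accounts for the step, and no measurement indicates how either aryl group acts at this position.

The exchange alters both the substituent and where it sits on the aryl group, so the compounds shown do not separate these two changes. On these data alone, it remains open whether an unsubstituted phenyl, or a phenyl carrying a methoxy group or a nitrile, would move the number further on this nitrogen, and whether the step carries over to the core of compound 1.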